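Rearranging the side chain of compound 1

The source may report more compounds than this note shows. Statements on the series, on what has been measured and on what is new or still open speak of the compounds shown alone.

In a functional assay on the whole organism with Mus musculus as the target (on this read-out higher numbers stand for an effect only at larger amounts of compound and lower numbers for an effect already at smaller amounts), compound 1 `CCCNC(=O)Cn1c(-c2ccc(Cl)cc2)nc2cccnc21` gives 37.5 mg/kg. Compound 2 `CN(C)CCNC(=O)Cn1c(-c2ccc(Cl)cc2)nc2cccnc21` gives 62 mg/kg and compound 3 `CN(C)CCCNC(=O)Cn1c(-c2ccc(Cl)cc2)nc2cccnc21` gives 64 mg/kg, so compound 1 stands level with both once the usual scatter is allowed for.

Compound 4 `C[C@@H](C(=O)N(C)C)n1c(-c2ccc(Cl)cc2)nc2cccnc21` has not yet been measured. It holds the same atoms as compound 1, joined differently: 1-(dimethylcarbamoyl)ethyl in place of (propylcarbamoyl)methyl on an aromatic nitrogen. In short, 1-(dimethylcarbamoyl)ethyl takes the place of (propylcarbamoyl)methyl on an aromatic nitrogen.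

Within the data shown here, no measured compound carries this new group, so the evidence is only indirect. Three measured steps, a 1.7-fold higher number from compound 1 to compound 2 (0.22 log units; within the scatter), a 1.7-fold higher number from compound 1 to compound 3 (0.23 log units; within the scatter) and a 1.0-fold higher number from compound 2 to compound 3 (0.01 log units; within the scatter), alter only the end of the chain on the amide nitrogen, and all stay within the scatter. On that basis, no change beyond the scatter is expected in this assay, in either direction. The estimated step is a 1.2-fold higher number from compound 1 to compound 4 (0.08 log units; within the scatter). For compound 4 the estimated value is 45 mg/kg, with an expected range from 18 mg/kg to 110 mg/kg.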

Compound 4, dose for half-maximal effect: 31.6 mg/kg
The estimate for compound 4 lay 1.4-fold (0.15 log units) above the measured number; the measured number falls inside the stated range.
By their numbers in this assay, from the lowest: compounds 4, 1, 2 and 3 (each within the scatter of the next, the first and the last beyond it).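

Until now, only the end of the chain on the amide nitrogen had changed, whereas compound 4 rearranges the whole group on the aromatic nitrogen. In this assay this gives a 1.2-fold lower number from compound 1 to compound 4 (0.07 log units; within the scatter), so removing the amide hydrogen and adding a defined stereocentre, both in one change, leaves compound 4 level with compound 1. Nothing measured here explains this result.

The compounds shown leave open what each part of the change contributes: a (dimethylcarbamoyl)methyl group would keep the two methyl groups on the amide nitrogen without the extra methyl on the chain, and the mirror-image form of compound 4 would isolate the stereocentre. Also open, going by these compounds, is whether a carboxylic acid in place of the amide would keep the number level at this position.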